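This account rests on a few compounds, and the source may have more. Where it says the series, first, only, none or still open, it means among the compounds named here.

Compounds measured so far:

Compound 1 `O=C(CCn1cnc2cc(-c3noc(CCc4ccccc4)n3)ccc21)N1CCCC1` — in a toxicity assay on HepG2 2.2.15 cells (Homo sapiens) for cytotoxicity, read by CCK-8 assay, with a stated time of 72 h (on this read-out higher numbers stand for lower toxicity in this test and lower numbers for higher toxicity in this test), compound 1 gives > 20000 nM, which is a limit of the assay and not a number.

Compound 2 `O=C(CCn1cnc2cc(-c3noc(CCC4CCCC4)n3)ccc21)N1CCCCC1` — in this assay compound 2 gives > 20000 nM, again a limit.

Compound 3 `O=C(CCn1cnc2cc(-c3noc(CCC4CCCC4)n3)ccc21)NC1CCCCC1` — in this assay compound 3 gives > 20000 nM, also a limit.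

Compound 3 therefore stands only at a limit, and the two other values shown are limits as well; all three sit at the limit of > 20000 nM in this assay, at which 3 of the 3 values shown sit. Within the data shown here, the one step between measured compounds that differ in a single place, a step that the two limits leave unreadable from compound 2 to compound 3, is unreadable, since both its ends are limits.

Compound 4 `Cc1ccccc1NC(=O)CCn1cnc2cc(-c3noc(CCC4CCCC4)n3)ccc21` differs from compound 3 by 2-methylphenyl in place of cyclohexyl on an amide-type nitrogen. Among the measured compounds shown here, no measured step bears on this change in a readable way: the only step available, from compound 2 to compound 3, shows neither size nor direction. For the measured compounds named here, what is known is only that compound 3 sits at the limit of > 20000 nM in this assay, at which 3 of the 3 values shown sit, like compounds 1 and 2.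

The step that the limit leaves unreadable from compound 3 to compound 4 is therefore expected to be none beyond the scatter, with a limit the most probable result. For compound 4 the estimate in this assay is 25000 nM, with a range from 12000 nM to 60000 nM.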

Compound 4, half-maximal cytotoxic concentration: > 20000 nM
Compound 4 ended at the assay's limit; the forecaster's own chance of this, stated with the estimate: 80%; the middle value is on the limit's open side.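

Among these compounds, compound 4 also gives a limit and not a number, so neither the step to it from compound 2 nor the one from compound 3 can be read: the limit of > 20000 nM in this assay, at which 4 of the 4 values shown sit. The compounds shown leave open what value each would reach in this assay and whether any of these changes alters it.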